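Swapping isopropylamino for octylsulfanyl in a cell toxicity test

A few compounds are considered here, and "the series" means these few. Any claim that something is new, unique, unknown or untested is made for them only; others in the source may bear on it.

- Compound 1 `CCCCCCCCOc1nc(N)nc2c1ncn2/C=C1/CC1(CO)CO`: > 300000 nM, a limit
- Compound 2 `CC(C)Nc1nc(N)nc2c1ncn2/C=C1/CC1(CO)CO`: > 300000 nM, a limit

Both compounds were tested in an ADME assay on HFF cells (Homo sapiens) for cytotoxicity, with a stated time of 8 days; on this read-out higher numbers stand for lower toxicity in this test and lower numbers for higher toxicity in this test. Compound 2 gives no exact number, only the limit > 300000 nM. Compound 1 also gives only a limit, > 300000 nM. All the measured evidence therefore comes down to one observation: the limit of > 300000 nM in this assay, at which 2 of the 2 values shown sit.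

The next compound, compound 3 `CCCCCCCCSc1nc(N)nc2c1ncn2/C=C1/CC1(CO)CO`, carries octylsulfanyl in place of isopropylamino on an aromatic carbon. Among the measured compounds shown here, the one measured step that bears on this change is a step that the two limits leave unreadable from compound 1 to compound 2, so it offers no size to carry over. Among the measured compounds, compound 1 has the group closest to octylsulfanyl, and its octyloxy group reached the limit > 300000 nM. Compound 3 is therefore expected to stay close to the top of the measurable range, and it may well return another limit. Any expected shift is small and toward lower numbers, and the estimated change is an at least 1.2-fold lower number from compound 2 to compound 3 (0.07 log units; that floor lies within the scatter). For compound 3 the estimated value is 250000 nM, with an expected range from 80000 nM to 300000 nM.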

Compound 3, half-maximal cytotoxic concentration: > 300000 nM
Compound 3: a limit, no number; the forecaster's own chance of this, stated with the estimate: 65%; middle value at least 1.2-fold (0.07 log units) from the limit.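

In this assay compound 3 gives > 300000 nM, a limit and not a number. Among the compounds shown here, no step among compound 1, compound 2 and compound 3 can be read, and all three agree in one observation: the limit of > 300000 nM in this assay, at which 3 of the 3 values shown sit. The compounds shown leave open whether octyloxy, isopropylamino and octylsulfanyl differ at all in this assay, as none gives an exact number.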